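Swapping acetyl for methyl on one oxygen

The source may hold more compounds than are shown below. What is called first, only, known or untested is meant among the compounds shown, and "the series" means these compounds.

compound 1 `CCOCc1c(C)coc1-c1ccc2c(c1OC)CCCC2(C)C` gives 17.7 uM
compound 2 `COC(=O)c1c(C)coc1-c1ccc2c(c1OC)CCCC2(C)C` gives 33.5 uM
compound 3 `COc1c(-c2occ(C)c2COC(C)=O)ccc2c1CCCC2(C)C` gives 16.7 uM

These values come from a functional assay on DU-145 cells (Homo sapiens) for cytotoxicity, read by sulforhodamine B assay, with a stated time of 3 days (on this read-out higher numbers stand for an effect only at larger amounts of compound and lower numbers for an effect already at smaller amounts), and lie close together. Compound 3 stands within the scatter of both other compounds (a 1.1-fold lower number from compound 1 to compound 3 (0.03 log units; within the scatter)) and (a 2.0-fold lower number from compound 2 to compound 3 (0.30 log units; within the scatter)), so it holds no clear rank among them.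

Compound 4 `COCc1c(C)coc1-c1ccc2c(c1OC)CCCC2(C)C` has not yet been measured. The change methyl in place of acetyl on an oxygen on a saturated carbon puts methyl in place of acetyl on an oxygen on a saturated carbon, turning acetoxymethyl into methoxymethyl. The closest evidence is the exchange of ethyl and acetyl on that same oxygen (a 1.1-fold lower number from compound 1 to compound 3 (0.03 log units; within the scatter)), which stayed within the scatter. Larger replacements on the aromatic carbon (a 1.9-fold higher number from compound 1 to compound 2 (0.28 log units; within the scatter)) and (a 2.0-fold lower number from compound 2 to compound 3 (0.30 log units; within the scatter)) also stayed within it. Three compounds are thin evidence, but no step beyond the scatter is expected in either direction, and the estimated step is a 1.0-fold higher number from compound 3 to compound 4 (0.01 log units; within the scatter) in size.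

For compound 4 the estimated value is 17 uM with an expected range from 9.5 uM to 31 uM in this assay.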

Compound 4, concentration for half-maximal effect: 17.5 uM
Compound 4: middle estimate off by 1.0-fold (0.01 log units), on the low side; the measured number falls inside the stated range.
By their numbers in this assay, from the lowest: compounds 3, 4, 1 and 2 (each within the scatter of the next).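

In this assay, putting methyl in place of acetyl on this oxygen, which turns acetoxymethyl into methoxymethyl, gives a 1.0-fold higher number from compound 3 to compound 4 (0.02 log units; within the scatter), so losing the carbonyl here brings no change that can be told from the scatter. Going from ethoxymethyl to methoxymethyl gives a 1.0-fold lower number from compound 1 to compound 4 (0.00 log units; within the scatter), which means that ethyl, acetyl and methyl on this oxygen now all lie within the scatter of one another. Methoxymethyl in place of methoxycarbonyl on the aromatic carbon gives a 1.9-fold lower number from compound 2 to compound 4 (0.28 log units; within the scatter), so this simple ether also stays within the scatter of the ester.

From the compounds shown here alone, whether a free hydroxyl, an amine or a carboxylic acid on this carbon would shift the number remains open, as does the effect of a much longer chain on the oxygen. Nothing at hand explains why these values lie so close together.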